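Two Bromines Added to the Best-Performing Hydrazone

A few compounds are considered here, and "the series" means these few. Any claim that something is new, unique, unknown or untested is made for them only; others in the source may bear on it.

Compound 1, `COc1cccc(/C=N/NC(=O)CSc2nnc(-c3ccncc3)o2)c1`, gives 13800 nM.
Compound 2, `O=C(CSc1nnc(-c2ccncc2)o1)N/N=C/c1ccccc1F`, gives 21800 nM.
Compound 3, `O=C(CSc1nnc(-c2ccncc2)o1)N/N=C/c1ccccc1O`, gives 4750 nM.

These three share one core and differ only in the aromatic ring attached to the carbon that carries a double bond to nitrogen. In a functional assay on MCF7 cells (Homo sapiens) for cytotoxicity, read by MTT assay, with a stated time of 48 h (a higher number here means a weaker inhibitor, a lower number a stronger inhibitor), compound 3 stands lowest of the three, with a step of a 2.9-fold lower number from compound 1 to compound 3 (0.46 log units; beyond the scatter) and a step of a 4.6-fold lower number from compound 2 to compound 3 (0.66 log units; beyond the scatter), both beyond the scatter, while a 1.6-fold higher number from compound 1 to compound 2 (0.20 log units; within the scatter) is within it.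

Compound 4, `O=C(CSc1nnc(-c2ccncc2)o1)N/N=C/c1cc(Br)cc(Br)c1O`, keeps the hydroxy group of compound 3 and adds two bromine atoms: 3,5-dibromo-2-hydroxyphenyl in place of 2-hydroxyphenyl on a carbon with a double bond to nitrogen. Among the compounds with values here, no measured step adds a halogen to a ring that already carries the hydroxy group; the only halogen seen, the fluoro of compound 2, is not the same atom and sat in a different pairing. The measured steps therefore bear only loosely on this change. A step of a 1.6-fold lower number from compound 3 to compound 4 (0.20 log units; within the scatter) is expected, most likely small, with a slight lean toward a lower number. Compound 4 is estimated at 3000 nM, with a range from 1000 nM to 10000 nM.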

Compound 4, half-maximal inhibitory concentration: 9010 nM
Compound 4: the middle estimate sits 3.0-fold (0.48 log units) below what was measured; measured number inside the range.
By their numbers in this assay, from the lowest: compounds 3, 4, 1 and 2 (each within the scatter of the next, the first and the last beyond it).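

In this assay adding two bromines to the hydroxy-bearing ring gives a 1.9-fold higher number from compound 3 to compound 4 (0.28 log units; within the scatter), so this position accepts the 3,5-dibromo-2-hydroxyphenyl group with no clear gain or loss. The comparison with the 3-methoxyphenyl ring also shows no clear separation, at a 1.5-fold lower number from compound 1 to compound 4 (0.19 log units; within the scatter), whereas the comparison with the 2-fluorophenyl ring gives a 2.4-fold lower number from compound 2 to compound 4 (0.38 log units; beyond the scatter), so the dibrominated ring keeps a modest edge over that ring, as the unbrominated 2-hydroxyphenyl ring did. Nothing available gives a reason for these steps.

From the compounds shown here alone, whether a single bromine would read like the pair remains open, since both bromines enter together here. Also open, going by these compounds, is what an amine or a carboxylic acid in place of the hydroxy group would give on the same ring.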